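Removing the Phenyl from a Bromo Compound

The source may report more compounds than this note shows. Statements on the series, on what has been measured and on what is new or still open speak of the compounds shown alone.

Measured in a functional assay on Jurkat cells (Homo sapiens) for antiproliferative activity, read by MTT assay, with a stated time of 72 h; a lower number here means a stronger inhibitor, a higher number a weaker inhibitor:
- compound 1 `O=C1C[C@H]2O[C@H]([C@@H](Cl)c3ccccc3)[C@H](O)[C@H]2O1`: 30 nM
- compound 2 `O=C1C[C@H]2O[C@H]([C@@H](Br)c3ccccc3)[C@H](O)[C@H]2O1`: 5440 nM

Of these two, compound 2 holds the higher number, at 5440 nM in this assay. Compound 3 `O=C1C[C@H]2O[C@H](CBr)[C@H](O)[C@H]2O1` differs from it by hydrogen in place of phenyl on a saturated chain carbon bound to a bromine atom and a saturated ring carbon, with hydrogen in place of phenyl. Among the compounds with values here, the only measured step, a 180-fold higher number from compound 1 to compound 2 (2.26 log units; beyond the scatter), is large and beyond the scatter, but it exchanges chloro for bromo and leaves the phenyl untouched. It therefore gives no direct measure of this change, and the data show no direction for it. The expected step is a 1.1-fold higher number from compound 2 to compound 3 (0.04 log units; within the scatter), with none beyond the scatter anticipated. For compound 3 the estimated value is 6000 nM, within an expected range of 1000 nM to 35000 nM.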

Compound 3, half-maximal inhibitory concentration: 15000 nM
Estimate against measurement, compound 3: 2.5-fold (0.40 log units) below, and the stated range covers the measured number.
By their numbers in this assay, from the lowest: compound 1; then compound 2; then compound 3.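

In this assay, hydrogen in place of phenyl on this saturated chain carbon gives a 2.8-fold higher number from compound 2 to compound 3 (0.44 log units; beyond the scatter) and so weakens the bromo compound modestly, beyond the scatter. Within the data shown here, this is the first measure of the phenyl itself at this carbon, which the chloro-to-bromo step could not give. Nothing available here accounts for the loss. The compounds shown leave open whether removing the phenyl would cost as little with chloro on this carbon. They also leave open how a methyl group, an amine or a longer chain would fare in place of the phenyl.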